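Swapping the Aryl Group on the Thiourea of Compound 2

This account rests on a few compounds, and the source may have more. Where it says the series, first, only, none or still open, it means among the compounds named here.

Measured compounds:
compound 1 `O=C(Nc1cccc([N+](=O)[O-])c1)N1CCN(S(=O)(=O)c2sccc2-c2ccccc2Oc2ccc(O)c(O)c2)CC1`: 9800 nM
compound 2 `O=S(=O)(NCCNC(=S)Nc1cccc(Cl)c1)c1ccc(-c2ccccc2OCc2ccccc2)s1`: > 50000 nM

Two compounds carry results in a functional assay on RS4-11 cells (Homo sapiens) for inhibition, read by CCK-8 assay, with a stated time of 48 h; a lower number here means a stronger inhibitor, a higher number a weaker inhibitor. Compound 1 `O=C(Nc1cccc([N+](=O)[O-])c1)N1CCN(S(=O)(=O)c2sccc2-c2ccccc2Oc2ccc(O)c(O)c2)CC1` gives 9800 nM. Compound 2 `O=S(=O)(NCCNC(=S)Nc1cccc(Cl)c1)c1ccc(-c2ccccc2OCc2ccccc2)s1` reaches only a limit of the assay, > 50000 nM, so its standing rests on the limit of > 50000 nM in this assay, at which 1 of the 2 values shown sits, and nothing closer is known. Compound 3 `O=[N+]([O-])c1ccc(NC(=S)NCCNS(=O)(=O)c2ccc(-c3ccccc3OCc3ccccc3)s2)cc1` has not been measured. It differs from compound 2 in one place: 4-nitrophenyl in place of 3-chlorophenyl on an amide-type nitrogen. For the measured compounds named here, no step between measured compounds follows this exchange, and compound 1 shares neither the thiourea nor the chain of compound 2, so its number gives no step to read across. Since compound 2 sits at the limit, the step from compound 2 to compound 3 is expected to be an at least 1.2-fold lower number from compound 2 to compound 3 (0.09 log units; that floor lies within the scatter), without a direction that the data can fix. Compound 3 is therefore estimated at 40000 nM, with a range from 10000 nM to 100000 nM.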

Compound 3, half-maximal inhibitory concentration: 11300 nM
Compound 3: middle estimate off by 3.5-fold (0.55 log units), on the high side, within the range that was stated.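

In this assay, putting 4-nitrophenyl in place of 3-chlorophenyl on the amide-type nitrogen gives a readable step at this position, an at least 4.4-fold lower number from compound 2 to compound 3 (0.64 log units; beyond the scatter), which shows that the aryl group on the thiourea bears on the read-out. This step is a floor and not a measured gap, and compound 2 stands only at a limit of the assay: the limit of > 50000 nM in this assay, at which 1 of the 3 values shown sits. One step cannot separate the identity of the substituent from its place on the ring, as both differ in this exchange.

On these data alone, it remains open whether 3-nitrophenyl or 4-chlorophenyl on the same nitrogen would match compound 3, and what an unsubstituted phenyl, an amine or a carboxylic acid there would give. Also open, as far as these compounds go, is how compound 3 would fare with a urea in place of the thiourea or with a longer chain.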